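Swapping Bromo for Chloro on the Aryl Ring

The compounds below may be only part of what the source reports. "The series", "measured", "known", "first", "only" and "open" are said of these compounds alone.

Of the compounds shown here, two sharing one core have been measured in an assay on HEK-293T cells for displacement of a labelled ligand from corticotropin-releasing factor receptor 1 (Homo sapiens), read by scintillation counting, with a stated time of 2 h; a higher number here means a weaker inhibitor, a lower number a stronger inhibitor. Compound 1 `CCCCN(CC)c1cc(C)nc2c1NC(=O)CN2c1ccc(C(C)(C)C)cc1Br` gives 4.2 nM. Compound 2 `CCCCN(CC)c1cc(C)nc2c1NC(=O)CN2c1ccc(Br)cc1Cl` gives 2.7 nM, the lower of the two numbers, though compound 1 sits close to it and the gap between them falls within the usual scatter, so the two cannot be ranked against each other.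

The next compound, compound 3 `CCCCN(CC)c1cc(C)nc2c1NC(=O)CN2c1ccc(Cl)cc1Cl`, differs from compound 2 by a single exchange: chloro in place of bromo on an aromatic carbon. Nothing in the two measured numbers shows how a bromo-to-chloro exchange at this spot acts in this assay, so no step in either direction can be counted on. The expectation is that the change from compound 2 to compound 3 stays within the scatter, with the step estimated as a 1.3-fold higher number from compound 2 to compound 3 (0.11 log units; within the scatter). Compound 3 is therefore expected to give about 3.5 nM, within a range from 1.5 nM to 8 nM.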

Compound 3, inhibition constant: 3.4 nM
For compound 3 the middle estimate is 1.0-fold (0.01 log units) above the measured one; low and high end bracket the measured number.
By their numbers in this assay, from the lowest: compounds 2, 3 and 1 (each within the scatter of the next).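

In this assay, for the compounds shown here, replacing 4-bromo-2-chlorophenyl with 2,4-dichlorophenyl gives a 1.3-fold higher number from compound 2 to compound 3 (0.10 log units; within the scatter), the first direct reading of this exchange at this spot on the aromatic ring. At this place, meta to a chloro group, bromo and chloro therefore cannot be told apart in this measurement, although one pair of compounds shows this only for the present core and its other groups. No measurement at hand offers an explanation for this result.

On these data alone, it remains open how the number would respond to fluoro, an amine or a carboxylic acid at the same spot. It is also unknown whether the same exchange of bromo for chloro would read the same way elsewhere on this ring.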